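Acetoxymethyl in place of methoxymethyl: a solubility estimate

The compounds below may be only part of what the source reports. "The series", "measured", "known", "first", "only" and "open" are said of these compounds alone.

Measured so far:
compound 1, `COCc1cc(N)c(Nc2ccc(C#N)cc2)cc1Oc1c(C)cc(C#N)cc1C`, 0.07 ug/mL
compound 2, `CC(=O)OCc1cc(N)c(Nc2ccc(C#N)cc2)cc1Oc1c(C)cc(C#N)cc1C`, 0.2 ug/mL
compound 3, `COCc1cc(N)c(Nc2ccc(C#N)cc2)cc1Oc1c(C)cc(/C=C/C#N)cc1C`, 0.11 ug/mL

Of the compounds shown here, three sharing one core have been tested in a physicochemical assay for solubility, read by HPLC, at pH 7.4; a higher number here means a more soluble compound, a lower number a less soluble compound. Compound 3 gives 0.11 ug/mL, which sits in the middle of the three numbers: the step of a 1.6-fold higher number from compound 1 to compound 3 (0.20 log units; within the scatter) lies within the scatter, and compound 2, the highest number, stands within the scatter of compound 3 as well, so no real order among the three can be claimed.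

Compound 4, `CC(=O)OCc1cc(N)c(Nc2ccc(C#N)cc2)cc1Oc1c(C)cc(/C=C/C#N)cc1C`, has not yet been measured. It differs from compound 3 in one place: acetyl in place of methyl on an oxygen on a saturated carbon. The same exchange has been seen once before, from compound 1 to compound 2, and there it read a 2.9-fold higher number from compound 1 to compound 2 (0.46 log units; beyond the scatter), a modest rise that lies just beyond the scatter. The other known step, a 1.6-fold higher number from compound 1 to compound 3 (0.20 log units; within the scatter), does not bear on this exchange.

On that single precedent a rise of similar size is expected for compound 4, namely a 2.7-fold higher number from compound 3 to compound 4 (0.44 log units; beyond the scatter). Going by the values given here, the value of compound 4 in this assay is therefore estimated at 0.3 ug/mL, with a plausible range from 0.12 ug/mL to 0.8 ug/mL, a range kept wide since only one step supports it.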

Compound 4, solubility: 0.49 ug/mL
Estimate against measurement, compound 4: 1.6-fold (0.21 log units) below; the measured number falls inside the stated range.
By their numbers in this assay, from the lowest: compounds 1, 3 and 2 (each within the scatter of the next, the first and the last beyond it); then compound 4.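

In this assay the exchange of methoxymethyl for acetoxymethyl now reads a 4.5-fold higher number from compound 3 to compound 4 (0.65 log units; beyond the scatter) and so repeats, in compounds carrying 2-cyanoethenyl, the rise of a 2.9-fold higher number from compound 1 to compound 2 (0.46 log units; beyond the scatter) that was first seen in compounds carrying cyano, with both steps beyond the scatter. Going by these compounds alone, the second change also looks different now: 2-cyanoethenyl in place of cyano gives a 2.5-fold higher number from compound 2 to compound 4 (0.39 log units; beyond the scatter) in the acetoxymethyl pair, while the methoxymethyl pair shows a 1.6-fold higher number from compound 1 to compound 3 (0.20 log units; within the scatter) and so this change passes beyond the scatter in only one of its two pairs. Nothing measured here gives a reason for either rise.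

As far as these compounds go, whether acetyl is special on this oxygen stays open, since a longer acyl chain such as butanoyl, or a group ending in a carboxylic acid or an amine, could read quite differently in this assay at the same place. From the compounds shown here alone, two pairs for each change are also a small base, so it remains unknown whether the acetyl step would repeat with an amine or a carboxylic acid in place of cyano.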